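The compounds below may be only part of what the source reports. "The series", "measured", "known", "first", "only" and "open" are said of these compounds alone.

Working notes on the series. Compound 1 `COc1ccc(-c2cn3cc(C4=CCN(C(=O)C5CCCCC5)CC4)ccc3n2)cc1OC` gives 7310 nM in a functional assay on A549 cells (Homo sapiens) for antiproliferative activity, read by MTT assay, with a stated time of 48 h; on this read-out lower numbers stand for stronger inhibition and higher numbers for weaker inhibition. Compound 2 `COc1ccc(-c2cn3cc(C4=CCN(C(=O)c5ccc(Cl)cc5)CC4)ccc3n2)cc1OC` gives 8970 nM in this assay, and compound 3 `COc1ccc(-c2cn3cc(C4=CCN(S(=O)(=O)C5CCCCC5)CC4)ccc3n2)cc1OC` gives 4490 nM. Compound 3 has the lowest of the three numbers, but its nearest neighbour is compound 1 at a 1.6-fold lower number from compound 1 to compound 3 (0.21 log units; within the scatter) and its furthest is compound 2 at a 2.0-fold lower number from compound 2 to compound 3 (0.30 log units; within the scatter), so none of the three is separated from the others beyond the scatter.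

Compound 4 `COc1ccc(-c2cn3cc(C4=CCN(C(=O)c5cccc(C(F)(F)F)c5)CC4)ccc3n2)cc1OC` has not yet been measured in this assay. Relative to compound 3 the change is (3-(trifluoromethyl)phenyl)carbonyl in place of cyclohexylsulfonyl on an amine nitrogen in a ring. Among the measured compounds shown here, three measured steps bear on it. The swap of a carbonyl for a sulfonyl on the same cyclohexyl group gave a 1.6-fold lower number from compound 1 to compound 3 (0.21 log units; within the scatter); the swap of cyclohexylsulfonyl for an aryl carbonyl gave a 2.0-fold lower number from compound 2 to compound 3 (0.30 log units; within the scatter); and the swap of cyclohexyl for 4-chlorophenyl on the carbonyl carbon gave a 1.2-fold higher number from compound 1 to compound 2 (0.09 log units; within the scatter). Every one of these lay within the scatter, so for compound 4 a step of roughly the size of a 2.0-fold lower number from compound 2 to compound 3 (0.30 log units; within the scatter) in reverse, a somewhat higher number, is expected, and nothing beyond the scatter is expected with confidence. Compound 4 is therefore estimated at 8000 nM in this assay, with a range of 4000 nM to 16000 nM, which corresponds to an expected step of a 1.8-fold higher number from compound 3 to compound 4 (0.25 log units; within the scatter).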

Compound 4, half-maximal inhibitory concentration: 3690 nM
Compound 4: middle estimate off by 2.2-fold (0.34 log units), on the high side, and the stated range ends above it.
By their numbers in this assay, from the lowest: compounds 4, 3, 1 and 2 (each within the scatter of the next, the first and the last beyond it).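

In this assay, replacing 4-chlorophenyl with 3-(trifluoromethyl)phenyl on the carbonyl carbon gives a 2.4-fold lower number from compound 2 to compound 4 (0.39 log units; beyond the scatter), the only step among these four compounds that lies beyond the scatter, though modestly, so the choice of aryl group at this position can shift the number. Two other changes stay within the scatter: (3-(trifluoromethyl)phenyl)carbonyl in place of cyclohexylsulfonyl gives a 1.2-fold lower number from compound 3 to compound 4 (0.09 log units; within the scatter), and 3-(trifluoromethyl)phenyl in place of cyclohexyl on the carbonyl carbon gives a 2.0-fold lower number from compound 1 to compound 4 (0.30 log units; within the scatter), so an aryl carbonyl on this amine nitrogen does not in itself go with a higher number than either cyclohexyl-bearing group. No supporting measurement is available to account for the difference between the two aryl groups.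

The step from compound 2 to compound 4 changes both the substituent on the phenyl ring and where it sits, and the compounds shown do not separate these two changes. As far as these compounds go, it also remains open how this position would respond to a phenyl ring carrying an amine or a carboxylic acid, or to a longer chain between the carbonyl and the ring.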